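A few compounds are considered here, and "the series" means these few. Any claim that something is new, unique, unknown or untested is made for them only; others in the source may bear on it.

Measured so far:
compound 1, `CCCSc1nc(N/N=C(\C)c2ccc(OC)cc2)c2nnn(Cc3ccccc3)c2n1`: > 64000 nM
compound 2, `CCCSc1nc(N/N=C/c2cccnc2)c2nnn(Cc3ccccc3)c2n1`: 58700 nM

In a functional assay on MCF7 cells (Homo sapiens) for antiproliferative activity, read by MTT assay, with a stated time of 72 h (on this read-out higher numbers stand for weaker inhibition and lower numbers for stronger inhibition), compound 2 `CCCSc1nc(N/N=C/c2cccnc2)c2nnn(Cc3ccccc3)c2n1` gives 58700 nM. Compound 1 `CCCSc1nc(N/N=C(\C)c2ccc(OC)cc2)c2nnn(Cc3ccccc3)c2n1` gives only > 64000 nM, which is a limit of the assay and not a number. Among the compounds with values here, compound 2 therefore stands as the only numerical value in this set, while the other measurement sits at the limit of > 64000 nM in this assay, at which 1 of the 2 values shown sits.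

Compound 3 `CCCSc1nc(N/N=C(\C)c2ccc(Br)cc2)c2nnn(Cc3ccccc3)c2n1` has not yet been measured in this assay. It differs from compound 2 in one place: a group of 10 heavy atoms (8 carbon, 1 nitrogen, 1 bromine; one six-membered aromatic ring of carbon only) in place of a group of 8 heavy atoms (6 carbon, 2 nitrogen; one six-membered aromatic ring with 1 hetero atom), on a nitrogen on an aromatic ring. Within the data shown here, no step between two measured compounds is available to size this change directly. What can be said is that compound 1, which gives only the limit > 64000 nM, resembles compound 3 more closely than compound 2 does. On that ground the step of a 1.3-fold higher number from compound 2 to compound 3 (0.11 log units; within the scatter) is expected to go toward weaker inhibition, beyond the usual scatter. Compound 3 is accordingly estimated at 75000 nM, within a range from 30000 nM to 200000 nM, with a real chance that only a limit is reported.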

Compound 3, half-maximal inhibitory concentration: 13000 nM
Beside the measured number, compound 3's estimate is 5.8-fold (0.76 log units) above it, outside the stated range (below it).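

In this assay, the change on an aromatic carbon gets its first size, with bromo in place of methoxy giving an at least 4.9-fold lower number from compound 1 to compound 3 (0.69 log units; beyond the scatter). The value of compound 1 in that step is a limit of the assay and not a number: the limit of > 64000 nM in this assay, at which 1 of the 3 values shown sits. On a nitrogen on an aromatic ring, the group of 10 heavy atoms in place of the group of 8 heavy atoms gives a 4.5-fold lower number from compound 2 to compound 3 (0.65 log units; beyond the scatter), and since compound 1 also carries a six-membered aromatic ring of carbon only, that ring alone does not go with the lower number, which points to the bromo as the place that separates compound 3 from compound 1.

Going by these compounds, whether bromo is special remains open, as a chloro, a fluoro or a plain hydrogen on the same aromatic carbon would show whether other groups there give a similar number. All three compounds also keep the propylthio chain and the benzyl group, so the effect of a longer chain or an amine at those places cannot be read from them.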